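This account rests on a few compounds, and the source may have more. Where it says the series, first, only, none or still open, it means among the compounds named here.

Measured so far in a functional assay on MCF7 cells (Homo sapiens) for inhibition, read by CCK-8 assay, with a stated time of 48 h; a higher number here means a weaker inhibitor, a lower number a stronger inhibitor:
compound 1 `COc1cc(-c2ccnc3cc(-c4ccc(F)cc4)nn23)cc(OC)c1OC`, 1280 nM
compound 2 `COc1cc(-c2ccnc3cc(-c4c[nH]c5ccccc45)nn23)cc(OC)c1OC`, 85 nM
compound 3 `C=Cc1ccc(-c2cc3nccc(-c4cc(OC)c(OC)c(OC)c4)n3n2)cc1`, 193 nM

Compound 2 holds the lowest number of the three: compound 3 stands a 2.3-fold higher number from compound 2 to compound 3 (0.36 log units; beyond the scatter), and compound 1 lies further off still, as a 15-fold lower number from compound 1 to compound 2 (1.18 log units; beyond the scatter) shows. Compound 4 `COc1cc(-c2ccnc3cc(-c4cccc(C)c4)nn23)cc(OC)c1OC` is the next step from compound 2: 3-methylphenyl in place of 1H-indol-3-yl on an aromatic carbon. Among the compounds with values here, two measured steps bear on this. The step of a 15-fold lower number from compound 1 to compound 2 (1.18 log units; beyond the scatter) shows how much the 4-fluorophenyl loses against the 1H-indol-3-yl; the step of a 2.3-fold higher number from compound 2 to compound 3 (0.36 log units; beyond the scatter) shows a smaller loss for the 4-vinylphenyl. A 3-methylphenyl is expected to land between these two, so a modest to large rise in this assay is expected, a 4.7-fold higher number from compound 2 to compound 4 (0.67 log units; beyond the scatter). Compound 4 is accordingly estimated at 400 nM, within a range of 150 nM to 1100 nM.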

Compound 4, half-maximal inhibitory concentration: 1080 nM
Estimate against measurement, compound 4: 2.7-fold (0.43 log units) below, and the stated range covers the measured number.
By their numbers in this assay, from the lowest: compound 2; then compound 3; then compounds 4 and 1 (each within the scatter of the next).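

In this assay, a small substituted phenyl at this carbon does not hold the level of the 1H-indol-3-yl (a 13-fold higher number from compound 2 to compound 4 (1.10 log units; beyond the scatter)). The 3-methylphenyl also falls short of the 4-vinylphenyl (a 5.6-fold higher number from compound 3 to compound 4 (0.75 log units; beyond the scatter)), yet cannot be separated from the 4-fluorophenyl (a 1.2-fold lower number from compound 1 to compound 4 (0.07 log units; within the scatter)), so the change of substituent on this phenyl shows no uniform effect. No available measurement explains these differences. Still open, going by these compounds, is whether the hydrogen-bond donor leaving with the 1H-indol-3-yl matters; a 1-methylindol-3-yl or a 3-aminophenyl would bear on this.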